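The source may hold more compounds than are shown below. What is called first, only, known or untested is meant among the compounds shown, and "the series" means these compounds.

Measured compounds:
- compound 2, `COc1cc(CNC(=O)/C=C/c2cccc(O)c2)ccc1OCc1nc(C)c(C)nc1C`: 3680 nM
- compound 3, `COc1cc(CNC(=O)/C=C/c2cccc(OCc3nc(C)c(C)nc3C)c2)ccc1OCc1nc(C)c(C)nc1C`: 8700 nM
- compound 1, `COc1cc(CNC(=O)/C=C/c2ccccc2OCc2nc(C)c(C)nc2C)ccc1O`: 12000 nM

All three were tested in a functional assay on SH-SY5Y cells (Homo sapiens) for cytotoxicity, read by MTT assay, with stated times of 24 h and 4 h; on this read-out lower numbers stand for an effect already at smaller amounts and higher numbers for an effect only at larger amounts of compound. Compound 2 gives the lowest number of the three, so it shows an effect at smaller amounts than compound 3 and compound 1; both of those gaps are larger than the usual scatter.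

Compound 4, `COc1cc(/C=C/C(=O)NCc2ccc(OCc3nc(C)c(C)nc3C)c(OC)c2)cc(OC)c1`, has not yet been measured. It differs from compound 2 in one place: 3,5-dimethoxyphenyl in place of 3-hydroxyphenyl on a double-bonded chain carbon bound to a double-bonded chain carbon. The free phenol of compound 2 is thus lost, and a ring carrying two methoxy groups takes its place.

Within the data shown here, only one measured step bears on this: a 2.4-fold higher number from compound 2 to compound 3 (0.37 log units; beyond the scatter). There, too, the hydroxyl hydrogen on that ring was replaced by a larger group, and the number rose modestly. Since compound 4 also loses that hydroxyl donor, a modest rise in the number is expected, giving a 2.0-fold higher number from compound 2 to compound 4 (0.31 log units; beyond the scatter). Compound 4 is therefore estimated at 7500 nM, with a likely range from 3000 nM to 18000 nM.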

Compound 4, half-maximal effective concentration: 8660 nM
The estimate for compound 4 lay 1.2-fold (0.06 log units) below the measured number; the range from low to high includes it.
By their numbers in this assay, from the lowest: compound 2; then compounds 4, 3 and 1 (each within the scatter of the next).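

In this assay the change to 3,5-dimethoxyphenyl gives a 2.4-fold higher number from compound 2 to compound 4 (0.37 log units; beyond the scatter) and so shows that the number also rises modestly when the substituents on this ring are exchanged outright, and not only when a larger group is attached to the hydroxyl oxygen. Compound 3 at 8700 nM and compound 4 at 8660 nM lie within the usual scatter of each other, so these two quite different replacements of the free hydroxyl cannot be told apart here.

Nothing available explains the rise or separates the loss of the hydroxyl from the arrival of the methoxy groups. Going by these compounds, how the number would respond to an amine or a carboxylic acid on this ring remains open, as does the response to a single methoxy group.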